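A few compounds are considered here, and "the series" means these few. Any claim that something is new, unique, unknown or untested is made for them only; others in the source may bear on it.

Of the compounds shown here, three sharing one core have been tested in a functional assay on MCF7 cells (Homo sapiens) for inhibition, read by sulforhodamine B assay, with a stated time of 48 h, tested at 10 uM; a lower number here means less inhibition, a higher number more inhibition at the concentration tested (going by the name of the read-out). Compound 1 `COc1ccc(-c2cn3ccnc3c(-c3ccc4ncn(C5CCCCC5)c4c3)n2)cc1` gives 80.2%. Compound 2 `CC(=O)c1ccc(-c2cn3ccnc3c(-c3ccc4ncn(C5CCCCC5)c4c3)n2)cc1` gives 12%, and compound 3 `Clc1ccc(-c2cn3ccnc3c(-c3ccc4ncn(C5CCCCC5)c4c3)n2)cc1` gives 21.8%. Compound 3 therefore stands second highest of the three numbers: it sits close to compound 2, as the step of a number 9.8 percentage points higher from compound 2 to compound 3 (within the scatter) lies within the scatter, while the step of a number 58.4 percentage points lower from compound 1 to compound 3 (beyond the scatter) and the step of a number 68.2 percentage points lower from compound 1 to compound 2 (beyond the scatter) are both large, setting compound 1 well apart from the other two.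

Compound 4 `Brc1ccc(-c2cn3ccnc3c(-c3ccc4ncn(C5CCCCC5)c4c3)n2)cc1` differs from compound 3 by the change (bromo in place of chloro on an aromatic carbon). Among the compounds with values here, no measured step swaps one halogen for another, so nothing among the three compounds speaks directly to this change. Within the data shown here, the only measured step that touches the chloro group, the step of a number 9.8 percentage points higher from compound 2 to compound 3 (within the scatter), was small and within the scatter, and exchanging one halogen for a similar one is a smaller change than any of the steps measured here. A step within the scatter is therefore expected in this assay, with no preferred direction. For compound 4 the estimate is 25%, with a range from 8% to 45%, which means an expected step of a number 3.2 percentage points higher from compound 3 to compound 4 (within the scatter).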

Compound 4, a percentage reported as inhibition, at one concentration (the size of the read-out at that concentration, not a potency): 46.4%
Estimate against measurement, compound 4: 21.4 percentage points below, outside the stated range (above it).
By their numbers in this assay, from the lowest: compounds 2 and 3 (each within the scatter of the next); then compound 4; then compound 1.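

Swapping one halogen for the next is not a silent change at this position: on an aromatic carbon para to a large group, bromo in place of chloro gives a number 24.6 percentage points higher from compound 3 to compound 4 (beyond the scatter) in this assay and so separates two substituents that each add a single heavy atom. The bromo compound also stands apart from both other groups, with a number 34.4 percentage points higher from compound 2 to compound 4 (beyond the scatter) and a number 33.8 percentage points lower from compound 1 to compound 4 (beyond the scatter), so the three earlier compounds' picture of methoxy set apart from the rest now gains an intermediate level. No measurement of any property accompanies these numbers, so nothing here accounts for the gap between the 4-chlorophenyl and 4-bromophenyl compounds.

From the compounds shown here alone, it remains open whether the next halogen, iodo, or the smaller fluoro would continue this order, and whether an ethoxy group or a hydroxyl group at the same place would keep the level seen with methoxy. Each number is also a reading at one concentration, so these compounds leave open how their potencies compare.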